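Methyl to iodo on the aryl ring of compound 1

A few compounds are considered here, and "the series" means these few. Any claim that something is new, unique, unknown or untested is made for them only; others in the source may bear on it.

Compound 1 `COc1ccccc1Oc1c(N)nc(-c2ccc(C)cc2)nc1Cl` gives > 80000 nM in a functional assay on A-375 cells (Homo sapiens) for cytotoxicity, read by CCK-8 assay, with a stated time of 24 h (a lower number here means a stronger inhibitor, a higher number a weaker inhibitor), a limit and not a number.
Compound 2 `COc1ccccc1Oc1c(N)nc(-c2ccc(F)cc2)nc1Cl` gives 28200 nM in this assay.

Compound 1 stands only at the limit of > 80000 nM in this assay, at which 1 of the 2 values shown sits, so its own position is known as a limit alone. Going by the values given here, the one measured step, an at least 2.8-fold lower number from compound 1 to compound 2 (0.45 log units; beyond the scatter), is the sole guide. Compound 3 `COc1ccccc1Oc1c(N)nc(-c2ccc(I)cc2)nc1Cl` carries iodo in place of methyl on an aromatic carbon. The fluoro step bears only loosely on an iodo swap, so a downward step is expected, an at least 2.0-fold lower number from compound 1 to compound 3 (0.30 log units; that floor lies within the scatter), yet with wide uncertainty. Compound 3 is estimated at 40000 nM, expected between 12000 nM and 150000 nM.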

Compound 3, half-maximal inhibitory concentration: 480 nM
Compound 3: middle estimate off by 83-fold (1.92 log units), on the high side, and the stated range ends above it.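

The choice of halogen on this aromatic carbon matters far more than the fluoro step alone suggested: iodo in place of methyl gives an at least 160-fold lower number from compound 1 to compound 3 (2.22 log units; beyond the scatter), and iodo in place of fluoro gives a 59-fold lower number from compound 2 to compound 3 (1.77 log units; beyond the scatter). The second step is the firmer measure of the change, because the first is only a floor set by a limit on compound 1: the limit of > 80000 nM in this assay, at which 1 of the 3 values shown sits.

As far as these compounds go, it remains open whether chloro or bromo on this carbon would fall between fluoro and iodo. Also open, from the compounds shown here alone, is whether a trifluoromethyl or methoxy group there would keep the low number of compound 3.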